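This account rests on a few compounds, and the source may have more. Where it says the series, first, only, none or still open, it means among the compounds named here.

Measured compounds and their values:
Compound 1 `COCCCN1CCC(c2nnc(-c3nc(C(C)C)n4ccccc34)o2)CC1` gives 67% in a functional assay on CHO cells for agonist activity at 5-hydroxytryptamine receptor 4 (Homo sapiens), read by a luciferase reporter and cAMP accumulation, with a stated time of 4 h; a lower number here means a smaller maximal response, a higher number a larger maximal response.
Compound 2 `CC(C)c1nc(C(=O)NC2CCN(CC3CCOC3)CC2)c2ccccn12` gives 81% in this assay.
Compound 3 `CC(C)c1nc(C(=O)NC[C@@H]2[C@H]3CN(C4CCOCC4)C[C@@H]23)c2ccccn12` gives 43% in this assay.

Among these three, compound 3 has the lowest maximal response. Its nearest neighbour is compound 1, whose value lies higher by more than the usual scatter, and compound 2 lies higher still, again beyond the scatter. No two of the measured compounds differ in only one place, so no single structural change can be tied to a measured step here.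

Compound 4 `COCC(C)(C)CN1C[C@@H]2[C@@H](CNC(=O)c3nc(C(C)C)n4ccccc34)[C@@H]2C1` has not yet been measured. It differs from compound 3 in one place: 2-(methoxymethyl)-2-methylpropyl in place of oxan-4-yl on an amine nitrogen in a ring. The group that leaves has one six-membered non-aromatic ring; the group that enters has no ring and one more heavy atom. Going by the values given here, there is no measured pair that isolates such a change, so the direction of the step is uncertain. With compound 3 at the bottom of the three numbers, the expected step in this assay is a modest rise, a number 12 percentage points higher from compound 3 to compound 4 (beyond the scatter), though a value within the scatter of compound 3 would not surprise. The estimated maximal response for compound 4 is 55%, with a range from 30% to 80%.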

Compound 4, largest response reached (Emax), in percent of the reference or control that the assay uses: 53%
The estimate for compound 4 lay 2 percentage points above the measured number; measured number inside the range.
By their numbers in this assay, from the lowest: compounds 3 and 4 (each within the scatter of the next); then compound 1; then compound 2.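

Going by these compounds alone, this is the first measured pair that differs in only one place, so the group on the amine nitrogen in a ring can be judged on its own. In this assay, replacing oxan-4-yl with 2-(methoxymethyl)-2-methylpropyl gives a number 10 percentage points higher from compound 3 to compound 4 (within the scatter) and so the maximal response does not separate these two groups, although one has a six-membered non-aromatic ring and the other has no ring. No measurement shown offers a reason for this result.

The compounds shown leave open whether a plain ethyl group or a chain ending in a carboxylic acid on this nitrogen would move the response beyond the scatter. They also leave open whether the same replacement would behave alike on the cores of compound 1 and compound 2.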